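The compounds below may be only part of what the source reports. "The series", "measured", "known", "first", "only" and "open" are said of these compounds alone.

Measured compounds:
- Compound 1, `CC[C@H](C)[C@H](NC(=O)CN(c1ncnc2c1ncn2C1CCCCO1)C1CC1)C(=O)OCc1ccccc1`, in a functional assay on the whole organism (Tail, strain ICR) with Mus musculus as the target, in the tail flick test, with a stated time of 60 min, at a dose of 25 umol/kg by the oral route (a lower number here means a weaker effect, a higher number a stronger effect of the compound at the dose given), gives 27.4%.
- Compound 2, `O=C(O)CC[C@H](NC(=O)CN(c1nc(Cl)nc2[nH]cnc12)C1CC1)C(=O)O`, in this assay gives 33.3%.

Only these two readings exist, and they lie within the usual scatter of each other, so compound 1 stands level with compound 2 rather than apart from it; neither can be called the stronger or the weaker of the pair. For the measured compounds named here, the two also differ in several places at once, so no single structural step between them can be traced, and only their two values can be read.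

Compound 3, `NC(=O)C[C@H](NC(=O)CN(c1ncnc2c1ncn2C1CCCCO1)C1CC1)C(=O)OCc1ccccc1`, has not yet been measured. It is compound 1 with one change: carbamoylmethyl in place of sec-butyl on a saturated chain carbon bound to an amide-type nitrogen and a carbonyl carbon. Going by the values given here, no measured pair shows what this kind of exchange does in this assay. Among the compounds with values here, there is no step to lean on. Within the data shown here, the only anchor is the reading of compound 1, and with nothing to indicate a direction, the step from compound 1 to compound 3 is expected to be small, a number 0.6 percentage points higher from compound 1 to compound 3 (within the scatter), that is, none beyond the scatter. Compound 3 is therefore estimated at 28%, most likely between 10% and 50%.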

Compound 3, a percentage reported as activity, at one dose (the size of the read-out at that dose, not a potency): 30.5%
For compound 3 the middle estimate is 2.5 percentage points below the measured one; the range from low to high includes it.
By their numbers in this assay, from the lowest: compounds 1, 3 and 2 (each within the scatter of the next).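

In this assay, putting carbamoylmethyl in place of sec-butyl on a saturated chain carbon bound to an amide-type nitrogen and a carbonyl carbon gives a number 3.1 percentage points higher from compound 1 to compound 3 (within the scatter). For the compounds shown here, this is the first comparison here in which only one place changes, and it adds something the two earlier readings could not: a side group made only of carbon can give way to one holding a nitrogen and an oxygen, with the same count of heavy atoms, and the reading does not move beyond the usual scatter at this single dose and time. No supporting measurement bears on what lies behind this level result.

From the compounds shown here alone, what other groups would do at this position stays open: a hydroxymethyl group, an aminobutyl chain or a longer straight carbon chain might leave the reading level or might shift it clearly. A single exchange at one dose also cannot say whether the two compounds would still read level at other doses or times, so this position is only lightly explored so far.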